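The source may hold more compounds than are shown below. What is called first, only, known or untested is meant among the compounds shown, and "the series" means these compounds.

Measured compounds:
compound 1 `CC1(C)OC[C@H](COc2nc(N3CCCCC3)c3nc(OC[C@H]4COC(C)(C)O4)nc(N4CCCCC4)c3n2)O1` gives 87%
compound 2 `COCCOc1nc(NCc2ccccc2)c2nc(OCCOC)nc(NCc3ccccc3)c2n1` gives 78%
compound 3 `C=CCOc1nc(N2CCCCC2)c2nc(OCC=C)nc(N3CCCCC3)c2n1` gives 52%

In a functional assay on L1210 cells (Mus musculus) for inhibition, read by thymidine incorporation, tested at 10 uM (a higher number here means a stronger effect of the compound at the concentration tested, a lower number a weaker effect), compound 1 has the highest of the three numbers. Compound 2 sits within the usual scatter of it, so no order between those two can be claimed, while compound 3 lies clearly lower. Compound 4 `CC1(C)OC[C@@H](COc2nc(N3CCCCC3)c3nc(OC[C@@H]4COC(C)(C)O4)nc(N4CCCCC4)c3n2)O1` has not yet been measured. It differs from compound 1 as follows: the two compounds have the same atoms and bonds and differ only in configuration as drawn: 2 of 2 stereo elements differ (all stereocentres are inverted: mirror images); a stereocentre at a saturated ring carbon is drawn S in compound 1 and R in compound 4; a stereocentre at a saturated ring carbon is drawn S in compound 1 and R in compound 4. Among the compounds with values here, no measured pair here shows what inverting every stereocentre does, so the size of the step is uncertain. Compound 4 is expected to give about 72%, somewhere between 45% and 92%. That estimate means an expected step of a number 15 percentage points lower from compound 1 to compound 4 (beyond the scatter), a modest drop, though a number close to compound 1 would not be surprising.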

Compound 4, a percentage reported as inhibition, at one concentration (the size of the read-out at that concentration, not a potency): 100%
Estimate against measurement, compound 4: 28 percentage points below; the measured number lies above the stated range.
By their numbers in this assay, from the lowest: compound 3; then compounds 2 and 1 (each within the scatter of the next); then compound 4.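

Inverting both stereocentres gives a number 13 percentage points higher from compound 1 to compound 4 (beyond the scatter) in this assay, so this position is sensitive to configuration as well as to which groups are attached. No other change can account for the step, because the structures offer only one difference: the fact that compounds 1 and 4 differ only in the configuration as drawn

The compounds shown leave open whether one stereocentre alone accounts for the step or both contribute. They also leave open how a side chain ending in an amine or a carboxylic acid would behave in place of these side chains.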